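The source may hold more compounds than are shown below. What is called first, only, known or untested is meant among the compounds shown, and "the series" means these compounds.

Compound 1, `C=CC(=O)Nc1ccc(Cn2nc(-c3ccc(Oc4ccccc4)cc3)cc2C(=O)O)cc1`: > 60000 nM
Compound 2, `C/C=C/C(=O)Nc1ccc(Cn2nc(-c3ccc(Oc4ccccc4)cc3)cc2C(=O)O)cc1`: > 60000 nM
Compound 3, `C=CC(=O)N1CCCC(n2nc(-c3ccc(Oc4ccccc4)cc3)cc2C(=O)O)C1`: > 60000 nM

In a functional assay on JeKo-1 cells (Homo sapiens) for inhibition, read by luminescence and CellTiter-Glo, with a stated time of 72 h (on this read-out lower numbers stand for stronger inhibition and higher numbers for weaker inhibition), compound 1 gives only a limit, > 60000 nM. Compound 2 also gives only a limit in this assay, > 60000 nM. Compound 3 likewise gives only a limit, > 60000 nM. All three values sit at the limit of > 60000 nM in this assay, at which 3 of the 3 values shown sit, so none of them is a number.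

Compound 2 differs from compound 1 by prop-1-en-1-yl in place of vinyl on a carbonyl carbon. The step that the two limits leave unreadable from compound 1 to compound 2 is therefore not readable. How the core of compound 3 differs from that of compound 1 is not broken down here.

Compound 4, `C/C=C/C(=O)N1CCCC(n2nc(-c3ccc(Oc4ccccc4)cc3)cc2C(=O)O)C1`, is not yet measured. It differs from compound 3 by prop-1-en-1-yl in place of vinyl on a carbonyl carbon. The surroundings differ: in compound 1 the carbonyl carbon's other neighbour is an amide-type nitrogen, in compound 3 an amide-type nitrogen in a ring, so this is the same kind of change rather than the same change.

The step from compound 3 to compound 4 is expected to be a step that the limit leaves unreadable from compound 3 to compound 4, because the earlier step that the two limits leave unreadable from compound 1 to compound 2 showed nothing readable and every value stands at the limit of > 60000 nM in this assay, at which 3 of the 3 values shown sit. Compound 4 is therefore estimated at 100000 nM in this assay, most likely again reported only as a limit.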

Compound 4, half-maximal inhibitory concentration: > 60000 nM
Compound 4: only a limit was reported; the forecaster's own chance of this, stated with the estimate: 85%; the middle value is on the limit's open side.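

Compound 4 also gives only a limit in this assay, > 60000 nM, so the step from compound 3 to compound 4 cannot be read, and every value now stands at the same limit: the limit of > 60000 nM in this assay, at which 4 of the 4 values shown sit.

The compounds shown leave open whether prop-1-en-1-yl in place of vinyl on a carbonyl carbon changes inhibition at all.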